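Series notes: chlorophenyl swap on the shared core

A few compounds are considered here, and "the series" means these few. Any claim that something is new, unique, unknown or untested is made for them only; others in the source may bear on it.

Compound 3 `Clc1ccc(-c2cc(-c3ccoc3)cc(-c3ccccc3Cl)n2)s1` gives 0% in an assay on isolated protein for inhibition of DNA topoisomerase 1 (Homo sapiens), with a stated time of 30 min, tested at 100 uM (a higher number here means more inhibition at the concentration tested (going by the name of the read-out), a lower number less inhibition), the lowest of the three measured numbers. Its nearest neighbour is compound 2 `Clc1ccc(-c2cc(-c3ccoc3)cc(-c3ccco3)n2)s1`, which gives 9.6%; the gap a number 9.6 percentage points lower from compound 2 to compound 3 (within the scatter) lies within the scatter. Far above both stands compound 1 `Cc1ccsc1-c1cc(-c2ccoc2)cc(-c2ccc(Cl)cc2)n1` with 85.9%; no single step connects compound 1 to compound 3, so those two values are merely set side by side.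

Compound 4 `Clc1ccc(-c2cc(-c3ccoc3)cc(-c3ccc(Cl)s3)n2)cc1` differs from compound 3 in one place: 4-chlorophenyl in place of 2-chlorophenyl on an aromatic carbon. For the measured compounds named here, no measured step bears directly on this exchange. Going by the values given here, the only measured step, from compound 2 to compound 3, concerns a different group and was small. Compound 1 shows that a 4-chlorophenyl group can sit in a compound with high inhibition, but compound 1 differs from compound 4 elsewhere as well, so this is suggestive only. The expectation for compound 4 is therefore a modest upward step a number 25 percentage points higher from compound 3 to compound 4 (beyond the scatter) with wide uncertainty. The estimated value for compound 4 is 25%, ranging from 0% to 75%.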

Compound 4, a percentage reported as inhibition, at one concentration (the size of the read-out at that concentration, not a potency): 2.3%
Beside the measured number, compound 4's estimate is 22.7 percentage points above it, and the stated range covers the measured number.
By their numbers in this assay, from the lowest: compounds 3, 4 and 2 (each within the scatter of the next); then compound 1.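

In this assay, this position does not separate the groups tried while 5-chlorothiophen-2-yl stays in the compound: 4-chlorophenyl in place of 2-chlorophenyl gives a number 2.3 percentage points higher from compound 3 to compound 4 (within the scatter), and 4-chlorophenyl in place of furan-2-yl gives a number 7.3 percentage points lower from compound 2 to compound 4 (within the scatter). With 4-chlorophenyl held at this position, 5-chlorothiophen-2-yl in place of 3-methylthiophen-2-yl gives a number 83.6 percentage points lower from compound 1 to compound 4 (beyond the scatter), so 4-chlorophenyl alone does not go with high inhibition, and the large difference follows the other group. No measurement at hand accounts for either result.

From the compounds shown here alone, whether 2-chlorophenyl or furan-2-yl would keep the high number alongside 3-methylthiophen-2-yl remains open, since the flat picture at this position comes only from compounds carrying 5-chlorothiophen-2-yl. Also open, going by these compounds, is how an amine or a carboxylic acid at this position would read out.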